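This account rests on a few compounds, and the source may have more. Where it says the series, first, only, none or still open, it means among the compounds named here.

Measured compounds:
compound 1, `S=C(Nc1ccccc1)N1N=C(c2ccc(Cl)cc2)CC1c1ccc2c(c1)OCCO2`, 195000 nM
compound 2, `COc1ccccc1C1=NN(C(=S)Nc2ccccc2)C(c2ccc3c(c2)OCCO3)C1`, 20300 nM

In a functional assay on A-375 cells (Homo sapiens) for antiproliferative activity, read by MTT assay, with a stated time of 48 h (on this read-out higher numbers stand for weaker inhibition of growth and lower numbers for stronger inhibition of growth), compound 2 gives the lowest of the two numbers; its nearest neighbour is compound 1, whose number in this assay is higher by a 9.6-fold lower number from compound 1 to compound 2 (0.98 log units; beyond the scatter). Compound 3, `Cc1ccc(C2=NN(C(=S)Nc3ccccc3)C(c3ccc4c(c3)OCCO4)C2)cc1C`, is not yet measured. It differs from compound 2 by 3,4-dimethylphenyl in place of 2-methoxyphenyl on a carbon with a double bond to nitrogen. For the measured compounds named here, the one measured step at this position, a 9.6-fold lower number from compound 1 to compound 2 (0.98 log units; beyond the scatter), shows that the aryl group on the carbon with a double bond to nitrogen can move the number by a modest amount, beyond the scatter, but no measured compound carries 3,4-dimethylphenyl there, so the direction for compound 3 is not settled by the data. With compound 2 at the low end of the two numbers, compound 3 is expected to return part of the way toward compound 1, a step of a 3.0-fold higher number from compound 2 to compound 3 (0.47 log units; beyond the scatter). The estimate for compound 3 in this assay is 60000 nM, within a range from 15000 nM to 200000 nM.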

Compound 3, concentration for 50% growth inhibition: 61300 nM
For compound 3 the middle estimate is 1.0-fold (0.01 log units) below the measured one, and the stated range covers the measured number.
By their numbers in this assay, from the lowest: compound 2; then compound 3; then compound 1.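

In this assay, the aryl group on the carbon with a double bond to nitrogen now has three measured forms, and 3,4-dimethylphenyl takes the middle place, with a 3.0-fold higher number from compound 2 to compound 3 (0.48 log units; beyond the scatter) and a 3.2-fold lower number from compound 1 to compound 3 (0.50 log units; beyond the scatter) as its two steps. The position therefore responds to a group made of carbon only, and the hydrogen-bond acceptor counted in 2-methoxyphenyl is absent from a compound that still falls below compound 1, though compound 2 remains the lowest of the series. Nothing at hand gives a reason for this order.

The compounds shown leave open how an unsubstituted phenyl or a 4-aminophenyl group would compare on this carbon. Since all three share the 2,3-dihydro-1,4-benzodioxin-6-yl group and the group of 9 heavy atoms, the steps also say nothing about those two places.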